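Swapping 2,6-difluorophenyl for phenyl in a well-tolerated compound

The compounds below may be only part of what the source reports. "The series", "measured", "known", "first", "only" and "open" are said of these compounds alone.

Compound 1 (`Fc1cccc(F)c1Cn1ccc2nc(-c3c(F)cccc3F)nc-2c1`) has been measured in an ADME assay on MDBK cells (Bos taurus) for cytotoxicity; a lower number here means that less compound is tolerated, a higher number that more compound is tolerated. There compound 1 gives > 100000 nM, which is a limit of the assay and not a number. Compound 3 (`Cc1ccn(Cc2c(F)cccc2F)c2nc(-c3c(F)cccc3F)nc1-2`) gives > 100000 nM, also a limit. Compound 2 (`Fc1cccc(F)c1Cn1c(-c2c(F)cccc2F)nc2ccncc21`) gives an actual number, 99000 nM. Compound 1 therefore stands at the limit of > 100000 nM in this assay, at which 2 of the 3 values shown sit.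

Compound 4 (`Fc1cccc(F)c1-c1nc2ccn(Cc3ccccc3)cc-2n1`) has phenyl in place of 2,6-difluorophenyl on a saturated chain carbon bound to an aromatic nitrogen. For the measured compounds named here, no measured pair shows the effect of this change, so no shift beyond the usual scatter is expected in this assay. The expected step is an at least 1.1-fold lower number from compound 1 to compound 4 (0.04 log units; that floor lies within the scatter). For compound 4 the estimated value is 90000 nM, with an expected range of 45000 nM to 100000 nM.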

Compound 4, half-maximal cytotoxic concentration: > 100000 nM
Compound 4: only a limit was reported; the forecaster's own chance of this, stated with the estimate: 55%; at least 1.1-fold (0.04 log units) between middle value and limit.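

Compound 1 and compound 4 each give only a limit of the assay in this assay, so the step between them cannot be read. The compounds shown leave open whether phenyl in place of 2,6-difluorophenyl changes the tolerated concentration at all.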